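Swapping fluoro for methoxy on a fused-ring cytotoxic series

This account rests on a few compounds, and the source may have more. Where it says the series, first, only, none or still open, it means among the compounds named here.

Measured compounds:
- Compound 1, `CC(=O)c1cc(-c2ccc(F)cc2)cc2cc(-c3ccc(F)cc3)[nH]c12`: 93.2%
- Compound 2, `COc1ccc(-c2cc3cc(-c4ccc(F)cc4)cc(C(C)=O)c3[nH]2)cc1`: 96.4%
- Compound 3, `CC(=O)c1cc(/C=C/c2ccc(F)cc2)cc2cc(-c3ccc(F)cc3)[nH]c12`: 82%

All three were tested in a functional assay on MCF7 cells (Homo sapiens) for cytotoxicity, read by MTT assay, with a stated time of 2 days, tested at 1 uM; a higher number here means a weaker effect of the compound at the concentration tested, a lower number a stronger effect. Compound 1 and compound 2 share a core and differ by one change, (methoxy in place of fluoro on an aromatic carbon). That change gave a number 3.2 percentage points higher from compound 1 to compound 2 (within the scatter), so the two compounds cannot be told apart in this assay.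

Compound 3 carries a different core from compound 1: 2-(4-fluorophenyl)ethenyl in place of 4-fluorophenyl on an aromatic carbon. This change gave a number 11.2 percentage points lower from compound 1 to compound 3 (beyond the scatter), and compound 3 is the strongest of the three measured compounds, since its values lie beyond the scatter from both compound 1 and compound 2.

Compound 4, `COc1ccc(-c2cc3cc(/C=C/c4ccc(F)cc4)cc(C(C)=O)c3[nH]2)cc1`, has not yet been measured. It relates to compound 3 exactly as compound 2 relates to compound 1: methoxy in place of fluoro on an aromatic carbon. The place of the change is the same word for word in both pairs, so this is the same change made on the core of compound 3 instead of the core of compound 1.

Because the earlier instance of this change gave a number 3.2 percentage points higher from compound 1 to compound 2 (within the scatter), the expected step here is small: a number 3 percentage points higher from compound 3 to compound 4 (within the scatter) is what the estimate assumes, an expectation resting only on that one prior pair. Compound 4 is therefore expected to give about 85% in this assay, estimated to lie between 75% and 95%.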

Compound 4, a percentage reported as activity, at one concentration (the size of the read-out at that concentration, not a potency): 97.3%
Beside the measured number, compound 4's estimate is 12.3 percentage points below it; the whole stated range lies below it.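

Methoxy in place of fluoro gave a number 15.3 percentage points higher from compound 3 to compound 4 (beyond the scatter) in this assay, a larger step on paper than the earlier one, yet the two steps cannot be told apart: the same change on two cores in this assay, a number 3.2 percentage points higher (within the scatter) from compound 1 to compound 2 and a number 15.3 percentage points higher (beyond the scatter) from compound 3 to compound 4, 12.1 percentage points apart, within the scatter of two such steps

The other change, 2-(4-fluorophenyl)ethenyl in place of 4-fluorophenyl, gave a number 0.9 percentage points higher from compound 2 to compound 4 (within the scatter), and it too cannot be told apart from its earlier instance, even though one step lies beyond the scatter and the other within it: the same change on two cores in this assay, a number 11.2 percentage points lower (beyond the scatter) from compound 1 to compound 3 and a number 0.9 percentage points higher (within the scatter) from compound 2 to compound 4, 12.1 percentage points apart, within the scatter of two such steps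

So these four compounds do not show that either change behaves differently on one core than on the other, but they do not prove that either carries over unchanged, since each comparison rests on only two pairs read at a single concentration.

The compounds shown leave open how an amine or a carboxylic acid on the same aromatic carbon would read in this assay, and whether any such group would separate the two cores more clearly. They also leave open what a longer chain in place of the ethenyl link would do, on a core carrying either fluoro or methoxy.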